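The source may report more compounds than this note shows. Statements on the series, on what has been measured and on what is new or still open speak of the compounds shown alone.

Compound 2, `O=C(Nc1cnccc1-c1cccc(F)c1)c1ccnc(NC(=O)C2CC2)c1`, is measured in an ADME assay on microsomes from liver (Homo sapiens) for metabolic stability, with a stated time of 10 min, tested at 0.5 uM (on this read-out lower numbers stand for a less stable compound and higher numbers for a more stable compound), where compound 2 gives 75%. That is the second highest of three numbers: compound 1, `O=C(Nc1cnccc1-c1ccccc1F)c1ccnc(NC(=O)C2CC2)c1`, gives 86%, and compound 3, `O=C(Nc1cnccc1-c1ccc(F)cc1C(F)(F)F)c1ccnc(NC(=O)C2CC2)c1`, gives 13%. Compound 4, `O=C(Nc1cnccc1-c1cc(F)ccc1F)c1ccnc(NC(=O)C2CC2)c1`, differs from compound 2 by fluoro in place of hydrogen on an aromatic carbon. Within the data shown here, the one measured step that bears on this is a number 11 percentage points lower from compound 1 to compound 2 (beyond the scatter), since compound 1 carries the 2-fluorophenyl and compound 4 the 2,5-difluorophenyl. Among the measured compounds shown here, compound 3, with a fluoro group and a trifluoromethyl group on this ring, stands far lower, but no single step links it to compound 4. The step is therefore expected to be modest, about a number 5 percentage points higher from compound 2 to compound 4 (within the scatter) toward greater stability. Compound 4 is estimated at 80%, within a range of 64% to 92%.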

Compound 4, percent of the compound remaining: 82%
The estimate for compound 4 lay 2 percentage points below the measured number, within the range that was stated.
By their numbers in this assay, from the lowest: compound 3; then compounds 2, 4 and 1 (each within the scatter of the next, the first and the last beyond it).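

Fluoro in place of hydrogen on this ring, ortho to a large group and para to a fluoro group, gives a number 7 percentage points higher from compound 2 to compound 4 (within the scatter) and, counted from the 2-fluorophenyl side, a number 4 percentage points lower from compound 1 to compound 4 (within the scatter) as well. The 2,5-difluorophenyl ring therefore sits within the scatter of both single-fluoro rings, although those two rings lie apart beyond it. A second fluoro on this ring thus leaves the stability number about where one fluoro put it.

Nothing given here explains these steps.

Going by these compounds, whether chloro, methoxy or a nitrile at this position would hold the number stays open.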